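This account rests on a few compounds, and the source may have more. Where it says the series, first, only, none or still open, it means among the compounds named here.

Measured so far in a functional assay on HEK293 cells (Homo sapiens), read by cAMP accumulation; a lower number here means that less compound is needed, a higher number that more compound is needed for the effect:

- compound 1, `CCCC1=C(C(=O)OCc2ccc(C(=O)NCCCN(C)C)cc2)C(c2cccc(C)c2)NC(=O)N1`, gives 1400 nM
- compound 2, `CCCC1=C(C(=O)OCc2ccc(C(=O)NCCCN3CCCCC3)cc2)C(c2cccc(C)c2)NC(=O)N1`, gives 1900 nM
- compound 3, `CCCC1=C(C(=O)OCc2ccccc2)C(c2cccc(C)c2)NC(=O)N1`, gives 5200 nM

Among these three numbers, compound 2 stands second highest. Its nearest neighbour is compound 1, and the two are within the scatter of this assay, so no order can be read between them; its furthest is compound 3, separated by a 2.7-fold higher number from compound 2 to compound 3 (0.44 log units; beyond the scatter). The step from compound 1 to compound 3, a 3.7-fold higher number from compound 1 to compound 3 (0.57 log units; beyond the scatter), is of similar modest size.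

Compound 4, `CCCC1=C(C(=O)OCc2ccc(C(=O)NCCCN3CCN(C)CC3)cc2)C(c2cccc(C)c2)NC(=O)N1`, differs from compound 2 in one place: 4-methylpiperazin-1-yl in place of piperidin-1-yl on a saturated chain carbon, three bonds along the chain from an amide-type nitrogen. The step that bears most directly on this is the exchange of one basic ring amine for another on the same chain, a 1.4-fold higher number from compound 1 to compound 2 (0.13 log units; within the scatter), which stayed within the scatter. The larger steps to compound 3 concern removing the whole side chain, not reshaping its end, so they do not point to a shift here. Compound 4 is therefore expected to show no step beyond the scatter, no change at the digits printed from compound 2 to compound 4 (within the scatter), and is estimated at 1900 nM with a range of 900 nM to 4000 nM.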

Compound 4, half-maximal effective concentration: 4300 nM
Estimate against measurement, compound 4: 2.3-fold (0.35 log units) below; measured number outside the range, above it.
By their numbers in this assay, from the lowest: compounds 1 and 2 (each within the scatter of the next); then compounds 4 and 3 (each within the scatter of the next).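

In this assay, the end of this chain is less forgiving than the earlier exchange of dimethylamino for piperidin-1-yl suggested: 4-methylpiperazin-1-yl in place of piperidin-1-yl gives a 2.3-fold higher number from compound 2 to compound 4 (0.35 log units; beyond the scatter) and, in place of dimethylamino, gives a 3.1-fold higher number from compound 1 to compound 4 (0.49 log units; beyond the scatter) as well. The benefit of carrying the side chain therefore depends on the group at its end. Compound 4 gives 4300 nM and compound 3, which has no side chain, gives 5200 nM, two values within the scatter of each other, so this end group leaves no readable advantage over hydrogen.

The compounds shown cannot separate the effect of the second ring nitrogen from that of its methyl, which a piperazin-1-yl or morpholin-4-yl end would help to do. No measurement shown gives a reason for this shift.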